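Hydroxyamide pair: tert-butyl to methylcyclopropylmethyl on second core

A few compounds are considered here, and "the series" means these few. Any claim that something is new, unique, unknown or untested is made for them only; others in the source may bear on it.

Measured so far:
compound 1 `CC1(C[C@@H](O)C(=O)N2N=CC[C@H]2C(=O)NCc2cc(Cl)ccc2-n2cnnn2)CC1` — 730 nM
compound 2 `CC(C)(C)[C@@H](O)C(=O)N1N=CC[C@H]1C(=O)NCc1cc(Cl)ccc1-n1cnnn1` — 1400 nM
compound 3 `CC(C)(C)[C@@H](O)C(=O)N1C[C@H]2C[C@H]2[C@H]1C(=O)NCc1cc(Cl)ccc1-n1cnnn1` — 1200 nM

All three numbers come from a functional assay on a cell-free system (plasma, Homo sapiens), with a stated time of 3 min; on this read-out lower numbers stand for stronger inhibition and higher numbers for weaker inhibition. Compound 1 and compound 2 share one core and differ only in the group on the saturated chain carbon bound to a carbonyl carbon and an oxygen on a saturated carbon: (1-methylcyclopropyl)methyl in place of tert-butyl on a saturated chain carbon bound to a carbonyl carbon and an oxygen on a saturated carbon. That single change gave a 1.9-fold lower number from compound 2 to compound 1 (0.28 log units; within the scatter). Compound 3 carries a different core with the tert-butyl group kept; how the two cores differ is not broken down here. In this assay compound 3 gives 1200 nM, and its values against compound 2 and compound 1 lie within the scatter, so no ordering among the three is read from them.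

Compound 4 `CC1(C[C@@H](O)C(=O)N2C[C@H]3C[C@H]3[C@H]2C(=O)NCc2cc(Cl)ccc2-n2cnnn2)CC1` is not yet measured. It relates to compound 3 exactly as compound 1 relates to compound 2, the same change at the same place: (1-methylcyclopropyl)methyl in place of tert-butyl on a saturated chain carbon bound to a carbonyl carbon and an oxygen on a saturated carbon. Among the compounds with values here, on the first core this change produced only a small step, so for the second core a step of similar size is expected, a 1.8-fold lower number from compound 3 to compound 4 (0.27 log units; within the scatter), resting on the single earlier instance a 1.9-fold lower number from compound 2 to compound 1 (0.28 log units; within the scatter) and on the value of compound 3, 1200 nM. From the compounds shown here alone, whether the second core carries the change the same way is unknown from one example, so the range is kept wide. For compound 4 in this assay the estimate is 650 nM, between 300 nM and 1400 nM.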

Compound 4, half-maximal inhibitory concentration: 500 nM
Compound 4: the middle estimate sits 1.3-fold (0.11 log units) above what was measured; the range from low to high includes it.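

On the core of compound 3, (1-methylcyclopropyl)methyl in place of tert-butyl gives a 2.4-fold lower number from compound 3 to compound 4 (0.38 log units; beyond the scatter) in this assay, a modest step and the only one of the two that stands clear of the usual scatter. Set beside the same change on the core of compound 1, the two steps do not differ: the same change on two cores in this assay, a 1.9-fold lower number (0.28 log units; within the scatter) from compound 2 to compound 1 and a 2.4-fold lower number (0.38 log units; beyond the scatter) from compound 3 to compound 4, 1.3-fold (0.10 log units) apart, within the scatter of two such steps. This supports the view that the change carries over between these two cores with a similar modest size in this read-out, but it rests on a single pair per core, the earlier step alone could not be told from scatter, and nothing here shows why the step arises or whether it would hold on any other core.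

The compounds shown leave open whether a longer chain, an amine or a carboxylic acid on the saturated chain carbon bound to a carbonyl carbon and an oxygen on a saturated carbon would give a lower or a higher number than (1-methylcyclopropyl)methyl on either core. They also leave open whether a step of this size would recur on a third core, and whether it would appear in any read-out other than this assay.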